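The source may report more compounds than this note shows. Statements on the series, on what has been measured and on what is new or still open speak of the compounds shown alone.

Measured so far in an assay on isolated protein for inhibition of protein deacetylase HDAC6 (Homo sapiens), read by mobility shift assay; on this read-out lower numbers stand for stronger inhibition and higher numbers for weaker inhibition:
compound 1 `Cc1ccc(CN(Cc2ccc(C(=O)NO)cc2)S(=O)(=O)c2c(F)c(F)c(F)c(F)c2F)cc1` gives 6 nM;
compound 2 `O=C(NO)c1ccc(CN(Cc2ccncc2)S(=O)(=O)c2c(F)c(F)c(F)c(F)c2F)cc1` gives 14 nM;
compound 3 `O=C(NO)c1ccc(CN(Cc2ccncc2)S(=O)(=O)c2cc(F)c(F)c(F)c2F)cc1` gives 11 nM.

Compound 3 holds the second highest number of the three, with compound 2 and compound 1 both within the scatter of it. Compound 4 `O=C(NO)c1ccc(CN(Cc2cccc(F)c2)S(=O)(=O)c2cc(F)c(F)c(F)c2F)cc1` differs from compound 3 by 3-fluorophenyl in place of pyridin-4-yl on a saturated chain carbon bound to a sulfonamide nitrogen. For the measured compounds named here, one measured step bears on this change: a 2.3-fold higher number from compound 1 to compound 2 (0.37 log units; beyond the scatter), where a six-membered aromatic ring of carbon only was exchanged for the pyridine ring. The step to compound 4 runs the other way, bringing back a ring of carbon only, so in this assay a modest move toward a lower number is expected, roughly that earlier step reversed. The expected step is a 1.6-fold lower number from compound 3 to compound 4 (0.20 log units; within the scatter). Compound 4 is estimated at 7 nM, with a range from 3 nM to 16 nM.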

Compound 4, half-maximal inhibitory concentration: 14 nM
Compound 4: the middle estimate sits 2.0-fold (0.30 log units) below what was measured; low and high end bracket the measured number.
By their numbers in this assay, from the lowest: compounds 1, 3, 2 and 4 (each within the scatter of the next, the first and the last beyond it).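

With a 1.3-fold higher number from compound 3 to compound 4 (0.10 log units; within the scatter), pyridin-4-yl and 3-fluorophenyl on this saturated chain carbon cannot be told apart in this assay. So a ring of carbon only does not by itself bring a lower number: the difference seen in a 2.3-fold higher number from compound 1 to compound 2 (0.37 log units; beyond the scatter), between 4-methylphenyl and pyridin-4-yl, does not carry over to this pair. Nothing available explains this.

Open, going by these compounds, is whether 3-fluorophenyl and 4-methylphenyl differ when the rest of the molecule is held the same. Also open, on these data alone, is whether a chain ending in an amine or a carboxylic acid on this carbon would move the number beyond the scatter.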